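Chain length and nitro group on a cyanoguanidine series

The source may hold more compounds than are shown below. What is called first, only, known or untested is meant among the compounds shown, and "the series" means these compounds.

Compound 1 `N#CN/C(=N\CCCNc1ccccc1[N+](=O)[O-])NCCCCOc1cccc(CN2CCCCC2)c1`: 7.85
Compound 2 `N#CN/C(=N\CCCNc1ccc(N=[N+]=[N-])cc1[N+](=O)[O-])NCCCCOc1cccc(CN2CCCCC2)c1`: 6.56
Compound 3 `N#CN/C(=N\CCNC(=O)c1ccccc1[N+](=O)[O-])NCCCCOc1cccc(CN2CCCCC2)c1`: 7.52

In a functional assay on cardiac atrium for antagonist activity at histamine H2 receptor (Cavia porcellus) (on this read-out lower numbers stand for lower potency and higher numbers for higher potency (the scale is a negative logarithm)), compound 3 stands second highest of the three; compound 1 lies a number 0.33 log units lower from compound 1 to compound 3 (beyond the scatter) above it, and compound 2 sits lowest after a number 1.29 log units lower from compound 1 to compound 2 (beyond the scatter). Compound 4 `N#CN/C(=N\CCCNC(=O)c1ccccc1)NCCCCOc1cccc(CN2CCCCC2)c1` differs from compound 3 by benzamidomethyl in place of ((2-nitrophenyl)carbonyl)amino on a saturated chain carbon, two bonds along the chain from a double-bonded nitrogen. Going by the values given here, the step from compound 1 to compound 3, which also changed the chain and the linking group, was modest; no measured step bears on dropping the nitro group alone. A small step in this assay is therefore expected, a number 0.08 log units higher from compound 3 to compound 4 (within the scatter), in either direction, and compound 4 is estimated at 7.6, within 7 to 8.2.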

Compound 4, negative logarithm of the antagonist equilibrium constant: 6.6
For compound 4 the middle estimate is 1.00 log units above the measured one; measured number outside the range, below it.
By their numbers in this assay, from the lowest: compounds 2 and 4 (each within the scatter of the next); then compound 3; then compound 1.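

Benzamidomethyl in place of ((2-nitrophenyl)carbonyl)amino at this chain carbon gives a number 0.92 log units lower from compound 3 to compound 4 (beyond the scatter), so the two aromatic amides are not interchangeable here. Benzoyl in place of 2-nitrophenyl on the amine nitrogen gives a number 1.25 log units lower from compound 1 to compound 4 (beyond the scatter), whereas benzoyl in place of 4-azido-2-nitrophenyl gives a number 0.04 log units higher from compound 2 to compound 4 (within the scatter). Nothing available explains these steps. The compounds shown leave open whether the drop goes with the nitro group or with the extra chain carbon that benzamidomethyl brings. Going by these compounds, how a chloro or an amino group in place of that nitro group would read also remains open.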